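A few compounds are considered here, and "the series" means these few. Any claim that something is new, unique, unknown or untested is made for them only; others in the source may bear on it.

Measured compounds: compound 1 `CCc1nc2ccccc2n1CCCCOc1ccc(C)c(C)c1` with 14 uM in an ADME assay on Vero cells (Chlorocebus sabaeus) for cytotoxicity, read by luminescence, with a stated time of 2 days; on this read-out lower numbers stand for higher toxicity in this test and higher numbers for lower toxicity in this test; compound 2 `CN1CCN(c2nc3ccccc3n2CCCCOc2ccccc2)CC1`, whose entry in this assay reads "not determined" (no result reported), so that no result was reported for it.

Going by the values given here, compound 1 is the only compound with a number in this assay, so it stands alone there: compound 2 gives no result to set beside it, and no change between two measured compounds is known. Compound 3 `CCc1nc2ccccc2n1CCCCOc1ccncc1` differs from compound 1 in one place pyridin-4-yl in place of 3,4-dimethylphenyl on an oxygen on a saturated carbon. Among the compounds with values here, with no measured pair to learn from, the size of this step in this assay cannot be read off from the data; the expectation is a modest step toward less toxicity, perhaps not beyond the scatter, given as a 2.1-fold higher number from compound 1 to compound 3 (0.33 log units; beyond the scatter). Compound 3 is therefore estimated at 30 uM in this assay, with a range from 10 uM to 90 uM.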

Compound 3, half-maximal toxic concentration: > 50 uM
Compound 3: no number, only a limit; the forecaster's own chance of this, stated with the estimate: 25%; middle value at least 1.6-fold (0.22 log units) away from the limit.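

In this assay, compound 3 gives only a limit, > 50 uM, and not a number. Pyridin-4-yl in place of 3,4-dimethylphenyl on an oxygen on a saturated carbon gives an at least 3.5-fold higher number from compound 1 to compound 3 (0.55 log units; beyond the scatter), which shows that the read-out responds to the group at this position and that this change moves it toward lower toxicity in this test. The step has a lower bound but no upper one, so its full size cannot be read: the limit of > 50 uM in this assay, at which 1 of the 3 values shown sits.

The compounds shown leave open whether the ring nitrogen or the loss of the two methyl groups carries the step, as the two arrive together in this single change. They also leave open how a pyrimidinyl group or a phenyl ring bearing a carboxylic acid would read at the same position.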